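Bromophenyl in place of the thiosemicarbazide arm on the core

The source may hold more compounds than are shown below. What is called first, only, known or untested is meant among the compounds shown, and "the series" means these compounds.

Compound 3 `Cc1cc(NNC(N)=S)nc(SCc2nc3ccccc3[nH]2)n1` stands at a limit in a functional assay on MGC-803 cells (Homo sapiens) for cytotoxicity, read by MTT assay, with a stated time of 72 h; a higher number here means a weaker inhibitor, a lower number a stronger inhibitor: it gives > 100000 nM, a limit of the assay rather than a number. Compound 2 `Cc1cc(N2CCCCC2)nc(SCc2nc3ccccc3[nH]2)n1` also sits at a limit, with > 100000 nM. Only compound 1 `Cc1cc(Nc2ccc(Cl)cc2)nc(SCc2nc3ccccc3[nH]2)n1` gives a number, 28200 nM. Compound 4 `Cc1cc(Nc2ccc(Br)cc2)nc(SCc2nc3ccccc3[nH]2)n1` differs from compound 3 by a group of 7 heavy atoms (6 carbon, 1 bromine; one six-membered aromatic ring of carbon only) in place of a group of 4 heavy atoms (1 carbon, 2 nitrogen, 1 sulfur; no ring), on a nitrogen on an aromatic ring. This change is close to the reverse of the step of an at least 3.5-fold higher number from compound 1 to compound 3 (0.54 log units; beyond the scatter), and the step of an at least 3.5-fold higher number from compound 1 to compound 2 (0.54 log units; beyond the scatter) points the same way, both resting on (the limit of > 100000 nM in this assay, at which 2 of the 3 values shown sit). The step is therefore expected to run back from the limit towards the range of the chlorophenyl analogue, as an at least 4.0-fold lower number from compound 3 to compound 4 (0.60 log units; beyond the scatter). Compound 4 is estimated at 25000 nM, with a range from 9000 nM to 70000 nM.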

Compound 4, half-maximal inhibitory concentration: 26800 nM
Beside the measured number, compound 4's estimate is 1.1-fold (0.03 log units) below it; measured number inside the range.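

On a nitrogen on an aromatic ring, 4-bromophenyl brings a measurable value where the thiosemicarbazide arm does not, giving an at least 3.7-fold lower number from compound 3 to compound 4 (0.57 log units; beyond the scatter), and (4-bromophenyl)amino in place of piperidin-1-yl on an aromatic carbon gives an at least 3.7-fold lower number from compound 2 to compound 4 (0.57 log units; beyond the scatter). Bromo in place of chloro gives a 1.1-fold lower number from compound 1 to compound 4 (0.02 log units; within the scatter), so the two halogens cannot be told apart in this assay. The first two steps give only a bound on their size: the limit of > 100000 nM in this assay, at which 2 of the 4 values shown sit.

The compounds shown leave open how a plain phenyl, a 4-methoxyphenyl or a 4-fluorophenyl on that nitrogen would read.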